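The source may report more compounds than this note shows. Statements on the series, on what has been measured and on what is new or still open speak of the compounds shown alone.

Three compounds were tested in an assay on isolated protein for binding affinity to corticotropin-releasing factor receptor 1 (Homo sapiens); on this read-out lower numbers stand for stronger inhibition and higher numbers for weaker inhibition. Compound 1 `CCCN(Cc1ccccc1)c1nc(C)nc(Nc2ccc(C)cc2)n1` has a propyl group on the benzylamine nitrogen of the core, while compound 2 `CCN(Cc1ccccc1)c1nc(C)nc(Nc2ccc(C)cc2)n1` and compound 3 `CCCN(Cc1ccccc1)c1nc(C)nc(Nc2c(CC)cccc2CC)n1` are its close relatives. In this assay compound 1 gives only a limit, > 10000 nM. Compound 2 likewise gives only a limit, > 10000 nM. Compound 3 too gives only a limit, > 10000 nM. The change from compound 1 to compound 2 is hydrogen in place of methyl on a saturated chain carbon, two bonds along the chain from a nitrogen on an aromatic ring, and the step it made, a step that the two limits leave unreadable from compound 1 to compound 2, cannot be sized because of the limit of > 10000 nM in this assay, at which 3 of the 3 values shown sit. How the core of compound 3 differs from the core of compound 1 is not broken down here; the two simply share the same limit.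

Compound 4 `CCc1cccc(CC)c1Nc1nc(C)nc(N(CC)Cc2ccccc2)n1` has not been measured in this assay. It differs from compound 3 by hydrogen in place of methyl on a saturated chain carbon, two bonds along the chain from a nitrogen on an aromatic ring, the same change as from compound 1 to compound 2, made at the same place. Going by the values given here, for the step from compound 3 to compound 4 the account expects a step that the limit leaves unreadable from compound 3 to compound 4, since the only earlier instance of this change, a step that the two limits leave unreadable from compound 1 to compound 2, left both partners at the limit. On that basis compound 4 is estimated at 15000 nM, with a range from 5000 nM to 50000 nM, and it is expected most likely to return only a limit again.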

Compound 4, inhibition constant: 1700 nM
Compound 4: middle estimate off by 8.8-fold (0.95 log units), on the high side; the measured number lies below the stated range.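

In this assay, the change of propyl to ethyl gives an at least 5.8-fold lower number from compound 3 to compound 4 (0.76 log units; beyond the scatter), so on the core of compound 3 this single change brings the read-out down from the limit to a measurable number, and the true size of the step could be larger than the printed minimum. On the core of compound 1, the same change leads to compound 2, which gives > 10000 nM, a limit of the assay and not a number. The new step therefore shows that the change can pay off on one core, but it does not show that the gain carries from one core to another, nor that the two cores respond differently, and the step on the core of compound 1 cannot be read because both of its partners sit at the limit: the limit of > 10000 nM in this assay, at which 3 of the 4 values shown sit.

The compounds shown leave open whether the trend continues on the core of compound 3 when the ethyl of compound 4 is replaced by a methyl group, or whether a cyclopropylmethyl group would serve as well. They also leave open whether a core carrying a methoxy group in place of the two ethyl groups on the aniline ring would keep the number seen for compound 4, 1700 nM.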